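Adding a Methoxy to a Weakly Cytotoxic Amide

A few compounds are considered here, and "the series" means these few. Any claim that something is new, unique, unknown or untested is made for them only; others in the source may bear on it.

Compound 1, `C=CC1=C(C(=O)NCCCCC)C(c2ccc(OC)cc2)OC1`, gives 36500 nM in a functional assay on A549 cells (Homo sapiens) for cytotoxicity, read by MTT assay, with a stated time of 24 h; a lower number here means a stronger inhibitor, a higher number a weaker inhibitor.
Compound 2, `C=CC1=C(C(=O)NCc2ccc(C)cc2)C(c2ccc(OC)cc2)OC1`, reaches only the limit > 100000 nM in this assay; this is a limit of the assay, not a number.
Compound 3, `C=CC1=C(C(=O)NCc2ccccc2)C(c2ccc(OC)cc2)OC1`, likewise stops at the limit > 100000 nM in this assay, which is a limit rather than a measured number.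

Compound 3 therefore stands at the weak end of what has been measured, sharing its limit with compound 2, as the limit of > 100000 nM in this assay, at which 2 of the 3 values shown sit, records. The steps from compound 1 to the two benzylic amides were an at least 2.7-fold higher number from compound 1 to compound 2 (0.43 log units; beyond the scatter) and an at least 2.7-fold higher number from compound 1 to compound 3 (0.43 log units; beyond the scatter), while the step from compound 2 to compound 3 is a step that the two limits leave unreadable from compound 2 to compound 3.

Compound 4, `C=CC1=C(C(=O)NCc2ccccc2)C(c2ccc(OC)c(OC)c2)OC1`, differs from compound 3 by methoxy in place of hydrogen on an aromatic carbon. For the measured compounds named here, none of the measured steps touches this ring; all three concern the group on the amide nitrogen. Going by the values given here, there is thus no measured step that bears directly on this change, and with compound 3 already at the limit, compound 4 is expected to remain near that limit, with the step of a number no higher from compound 3 to compound 4 (the limit leaves the size open) estimated as small. Compound 4 is expected to give about 100000 nM, within 40000 nM to 250000 nM.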

Compound 4, half-maximal inhibitory concentration: > 100000 nM
Compound 4 gave a limit, no number (the forecaster's own chance of this, stated with the estimate: 65%); the middle value lies on the limit itself.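

Compound 3 and compound 4 both stop at a limit of the assay rather than a number, so no step between them can be read: the limit of > 100000 nM in this assay, at which 3 of the 4 values shown sit.

The compounds shown leave open what methoxy in place of hydrogen on an aromatic carbon does in this assay to a compound whose value lies clear of that limit.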